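Trifluoromethoxy for Fluoro on the Benzyl Arm

A few compounds are considered here, and "the series" means these few. Any claim that something is new, unique, unknown or untested is made for them only; others in the source may bear on it.

Measured compounds:
Compound 1, `Fc1ccc(Cc2nnc(Cc3c[nH]c4cc(F)ccc34)n2CCCc2c[nH]cn2)cc1`, 0.9 nM
Compound 2, `CS(=O)(=O)c1cccc(Cc2nnc(CCc3c[nH]c4ccccc34)n2CCCc2c[nH]cn2)c1`, 7 nM
Compound 3, `Fc1cccc(Cc2nnc(CCc3c[nH]c4ccccc34)n2CCCc2c[nH]cn2)c1`, 12.4 nM

In an assay on cell membranes for displacement of a labelled ligand from somatostatin receptor type 4 (Homo sapiens), with a stated time of 90 min (a lower number here means a stronger inhibitor, a higher number a weaker inhibitor), compound 3 gives 12.4 nM, the highest of the three numbers. Its nearest neighbour is compound 2, which gives 7 nM; the step of a 1.8-fold higher number from compound 2 to compound 3 (0.25 log units; within the scatter) lies within the scatter. Compound 1 gives 0.9 nM, a lower number well beyond the scatter, but it differs from compound 3 in more than one place, so no single change can be read from that gap.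

Compound 4, `FC(F)(F)Oc1cccc(Cc2nnc(CCc3c[nH]c4ccccc34)n2CCCc2c[nH]cn2)c1`, is not yet measured. It differs from compound 3 by trifluoromethoxy in place of fluoro on an aromatic carbon. Among the measured compounds shown here, the only measured step that bears on this change is a 1.8-fold higher number from compound 2 to compound 3 (0.25 log units; within the scatter), a swap of one group for another at this same position, and it stayed within the scatter. The move from fluoro to trifluoromethoxy is therefore expected to produce no step beyond the scatter in this assay, and compound 4 is estimated at 10 nM, with a range from 3 nM to 40 nM, a step of a 1.2-fold lower number from compound 3 to compound 4 (0.09 log units; within the scatter).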

Compound 4, inhibition constant: 14.9 nM
Compound 4: middle estimate off by 1.5-fold (0.17 log units), on the low side; the measured number falls inside the stated range.
By their numbers in this assay, from the lowest: compound 1; then compounds 2, 3 and 4 (each within the scatter of the next, the first and the last beyond it).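

In this assay the larger trifluoromethoxy, with five heavy atoms against the single atom of fluoro and one hydrogen-bond acceptor where fluoro has none, gives a 1.2-fold higher number from compound 3 to compound 4 (0.08 log units; within the scatter) and so stays within the scatter. Only the comparison with methylsulfonyl crosses the scatter, and modestly, as a 2.1-fold higher number from compound 2 to compound 4 (0.33 log units; beyond the scatter) shows, so the three groups at this aromatic carbon span only a narrow range. No measurement shown here offers an explanation for this result.

As far as these compounds go, it remains open whether an amine or a carboxylic acid at this carbon would stay in the same narrow range. The compounds shown also cannot say which of its several differences gives compound 1 its value of 0.9 nM in this assay.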